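Anilino-series antiproliferative notes: from compound 3 to compound 4

This account rests on a few compounds, and the source may have more. Where it says the series, first, only, none or still open, it means among the compounds named here.

Measured so far in an ADME assay on L02 cells (Homo sapiens) for antiproliferative activity, read by MTT assay, with a stated time of 48 h; a higher number here means a weaker inhibitor, a lower number a stronger inhibitor:
- compound 1 `N#CC1=C(N)Oc2c(c3nc4ccccc4nc3c3ccccc23)C12C(=O)N(Cc1cnnn1-c1ccc(Br)cc1)c1ccccc12`: in this assay compound 1 is reported only as the limit > 50000 nM.
- compound 2 `Cc1ccc(C)c(-n2nncc2CN2C(=O)C3(C(C#N)=C(N)Oc4c3c3nc5ccccc5nc3c3ccccc43)c3ccccc32)c1`: in this assay compound 2 is reported only as the limit > 50000 nM.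
- compound 3 `COc1ccc(-n2nncc2CN2C(=O)C3(C(C#N)=C(N)Oc4c(N)cc5nc6ccccc6nc5c43)c3ccccc32)cc1`: in this assay compound 3 is reported only as the limit > 50000 nM.

Compound 3 therefore stands at the limit that all three measured values share, as summarised by the limit of > 50000 nM in this assay, at which 3 of the 3 values shown sit. No number sits below that limit anywhere in the series as it stands. Among the compounds with values here, the one step that differs in a single place, a step that the two limits leave unreadable from compound 1 to compound 2, is not readable, since both ends of it are limits.

Compound 4 `Cc1cc(C)c(-n2nncc2CN2C(=O)C3(C(C#N)=C(N)Oc4c(N)cc5nc6ccccc6nc5c43)c3ccccc32)c(C)c1` carries the change (2,4,6-trimethylphenyl in place of 4-methoxyphenyl on an aromatic nitrogen). Within the data shown here, the only comparable change is the one from compound 1 to compound 2, and it gives no size. With every value shown at the limit, the expectation for compound 4 is that it also returns only a limit in this assay, and the step of a number no higher from compound 3 to compound 4 (the limit leaves the size open) is expected to be unreadable in the same way. The estimate for compound 4 in this assay is 50000 nM, with a range from 20000 nM to 50000 nM.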

Compound 4, half-maximal inhibitory concentration: > 50000 nM
Compound 4 gave a limit, no number; the forecaster's own chance of this, stated with the estimate: 85%; the middle value lies on the limit itself.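

In this assay, within the data shown here, compound 3 and compound 4 are both reported only as limits, so no step between them can be read. The compounds shown leave open how far each lies past its limit, and whether 2,4,6-trimethylphenyl and 4-methoxyphenyl differ at all in this read-out.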